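Taking one methyl from compound 1

The source may report more compounds than this note shows. Statements on the series, on what has been measured and on what is new or still open speak of the compounds shown alone.

Compound 1 (`Cc1ccc([C@@H](C)Oc2cc3onc(CCC(=O)O)c3cc2Cl)nc1`) gives > 860 ug/mL in a physicochemical assay for solubility, with a stated time of 24 h (on this read-out higher numbers stand for higher solubility and lower numbers for lower solubility), as its result, which is a limit and not a number. Compound 4 (`C[C@@H](Oc1cc2onc(CCC(=O)O)c2cc1Cl)c1ccccn1`) changes 5-methylpyridin-2-yl to pyridin-2-yl, hydrogen in place of methyl on an aromatic carbon. Among the measured compounds shown here, only one measured step lies nearby, and it sits on another core. Compound 2 (`O=C(O)CCn1c(=O)oc2cc(Cl)c(Cl)cc21`) gives 270 ug/mL in the same test. Compound 3 (`O=C(O)CCn1c(=O)oc2cc(OCC3CC3)c(Cl)cc21`) gives > 2060 ug/mL as its result, again a limit. That step (an at least 7.6-fold higher number from compound 2 to compound 3 (0.88 log units; beyond the scatter)) swaps chloro for cyclopropylmethoxy, a different and larger change, so it bears only weakly here. The expected step (a step that the limit leaves unreadable from compound 1 to compound 4) therefore stays within the usual scatter. Compound 4 is estimated at 1200 ug/mL (expected range 600 ug/mL to 2500 ug/mL).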

Compound 4, solubility: > 7440 ug/mL
Compound 4: no number, only a limit; the forecaster's own chance of this, stated with the estimate: 65%; at least 6.2-fold (0.79 log units) between middle value and limit.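

Compound 1 and compound 4 each give only a limit in this assay, and the step between them cannot be read. The compounds shown leave open whether going from 5-methylpyridin-2-yl to pyridin-2-yl shifts solubility at all, and by how much.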